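Ester variation at a limit of the antiproliferation assay

The compounds below may be only part of what the source reports. "The series", "measured", "known", "first", "only" and "open" are said of these compounds alone.

Three esters of a shared core have been tested in a functional assay on SK-BR-3 cells (Homo sapiens) for antiproliferative activity, read by MTT assay, with a stated time of 72 h; a higher number here means a weaker inhibitor, a lower number a stronger inhibitor. Compound 1 `C/C=C1/[C@H](O[C@@H]2O[C@H](COC(C)=O)[C@@H](OC(C)=O)[C@H](OC(C)=O)[C@H]2OC(C)=O)OC=C(C(=O)OC)[C@H]1CC(=O)OCC` reaches only the limit of the assay, giving > 15000 nM. Compound 2 `C/C=C1/[C@H](O[C@@H]2O[C@H](COC(C)=O)[C@@H](OC(C)=O)[C@H](OC(C)=O)[C@H]2OC(C)=O)OC=C(C(=O)OC)[C@H]1CC(=O)OCCC(C)C` likewise gives only a limit, > 15000 nM. Compound 3 `C=C(C)CCOC(=O)C[C@@H]1C(C(=O)OC)=CO[C@@H](O[C@@H]2O[C@H](COC(C)=O)[C@@H](OC(C)=O)[C@H](OC(C)=O)[C@H]2OC(C)=O)/C1=C/C` also stands only at a limit, with > 15000 nM. The steps a step that the two limits leave unreadable from compound 1 to compound 2, a step that the two limits leave unreadable from compound 1 to compound 3 and a step that the two limits leave unreadable from compound 2 to compound 3 cannot be sized since (the limit of > 15000 nM in this assay, at which 3 of the 3 values shown sit). Compound 4 `C#CCOC(=O)C[C@@H]1C(C(=O)OC)=CO[C@@H](O[C@@H]2O[C@H](COC(C)=O)[C@@H](OC(C)=O)[C@H](OC(C)=O)[C@H]2OC(C)=O)/C1=C/C` differs from compound 3 by ethynyl in place of 2-methylprop-2-en-1-yl on a saturated chain carbon bound to an oxygen next to a carbonyl group. Among the compounds with values here, no measured step gives a readable size, so no movement in this assay beyond the scatter can be expected in either direction. Compound 4 is therefore estimated at 20000 nM, between 8000 nM and 60000 nM. The step that the limit leaves unreadable from compound 3 to compound 4 is expected to stay within the scatter, most likely again as a limit.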

Compound 4, half-maximal inhibitory concentration: > 15000 nM
Compound 4 ended at the assay's limit; the forecaster's own chance of this, stated with the estimate: 80%; the middle value lies beyond the limit too.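

Compound 4 sits at the same limit as compound 1, compound 2 and compound 3, so none of the steps among them can be read: the limit of > 15000 nM in this assay, at which 4 of the 4 values shown sit.

The compounds shown leave open how these esters of the shared core would rank in this assay.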